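A few compounds are considered here, and "the series" means these few. Any claim that something is new, unique, unknown or untested is made for them only; others in the source may bear on it.

In a functional assay on HeLa cells (Homo sapiens) for antiproliferative activity, with a stated time of 24 h (on this read-out higher numbers stand for weaker inhibition and lower numbers for stronger inhibition), compound 3 `Cc1ccccc1NC(=S)N1CCc2c(sc(NC(=O)c3ccccc3Cl)c2C(N)=O)C1` gives only a limit of the assay, > 50000 nM. Compound 1 `N#Cc1ccccc1CN1CCc2c(sc(NC(=O)c3ccccc3Cl)c2C(N)=O)C1` likewise gives only a limit, > 50000 nM. Compound 2 `NC(=O)c1c(NC(=O)c2ccccc2Cl)sc2c1CCN(Cc1c(Cl)cccc1Cl)C2` gives 28800 nM. Compound 4 `NC(=O)c1c(NC(=O)c2ccccc2Cl)sc2c1CCN(C(=S)Nc1c(Cl)cccc1Cl)C2` differs from compound 3 by 2,6-dichlorophenyl in place of 2-methylphenyl on an amide-type nitrogen. The nearest measured step puts the same entering group onto a different nitrogen: an at least 1.7-fold lower number from compound 1 to compound 2 (0.23 log units; that floor lies within the scatter), a step that stays within the scatter. In the other direction, an at least 1.7-fold higher number from compound 2 to compound 3 (0.23 log units; that floor lies within the scatter) is also no larger than the scatter. Because of the limit of > 50000 nM in this assay, at which 2 of the 3 values shown sit, any shift the change brings is expected to be small. Compound 4 is therefore expected at 40000 nM, between 15000 nM and 100000 nM. The step of an at least 1.2-fold lower number from compound 3 to compound 4 (0.09 log units; that floor lies within the scatter) is thus estimated to stay within the scatter.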

Compound 4, half-maximal inhibitory concentration: 26500 nM
Beside the measured number, compound 4's estimate is 1.5-fold (0.18 log units) above it, within the range that was stated.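

On the amide-type nitrogen, 2,6-dichlorophenyl in place of 2-methylphenyl gives an at least 1.8-fold lower number from compound 3 to compound 4 (0.27 log units; that floor lies within the scatter), so this thiocarbonyl series now has a measured number in this assay rather than only a limit. On the amine nitrogen in a ring, the larger thiocarbonyl group and the benzyl-type group carrying the same 2,6-dichlorophenyl show a 1.1-fold lower number from compound 2 to compound 4 (0.04 log units; within the scatter), while the comparison with the 2-cyanophenyl compound shows an at least 1.8-fold lower number from compound 1 to compound 4 (0.27 log units; that floor lies within the scatter). The true size of the two limited steps stays unknown because of this ceiling: the limit of > 50000 nM in this assay, at which 2 of the 4 values shown sit.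

Still open, going by these compounds, is what a methoxy group or an amine on the phenyl ring would do at this amide-type nitrogen. On these data alone, a simple alkyl chain in place of the ring is equally open.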